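A few compounds are considered here, and "the series" means these few. Any claim that something is new, unique, unknown or untested is made for them only; others in the source may bear on it.

For the measured compounds named here, the three compounds measured so far share one core and differ only in the group carried on one aromatic carbon. In a physicochemical assay for solubility (a lower number here means a less soluble compound, a higher number a more soluble compound), compound 1 `O=S(=O)(Nc1nccs1)c1ccc2c(c1)OCC[C@@H]2c1ccc(C(F)(F)F)cc1-c1ccc(F)cn1` gives 7000 nM, compound 2 `O=S(=O)(Nc1nccs1)c1ccc2c(c1)OCC[C@@H]2c1ccc(C(F)(F)F)cc1N1CCNCC1` gives 288000 nM, and compound 3 `Cn1nccc1-c1cc(C(F)(F)F)ccc1[C@H]1CCOc2cc(S(=O)(=O)Nc3nccs3)ccc21` gives 83000 nM. Compound 3 thus holds the second highest of the three numbers: the step of a 3.5-fold lower number from compound 2 to compound 3 (0.54 log units; beyond the scatter) separates it from the highest, and the step of a 12-fold higher number from compound 1 to compound 3 (1.07 log units; beyond the scatter) from the lowest.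

Compound 4 `O=S(=O)(Nc1nccs1)c1ccc2c(c1)OCC[C@@H]2c1ccc(C(F)(F)F)cc1-c1ccc(F)cc1` is the next compound, not yet measured in this assay. It differs from compound 3 in this way: 4-fluorophenyl in place of 1-methyl-1H-pyrazol-5-yl on an aromatic carbon

Going by the values given here, two measured steps bear on this. The step of a 12-fold higher number from compound 1 to compound 3 (1.07 log units; beyond the scatter) shows that exchanging the group on this carbon for the 1-methyl-1H-pyrazol-5-yl ring went with a large rise, and the step of a 41-fold higher number from compound 1 to compound 2 (1.61 log units; beyond the scatter) shows an even larger rise for piperazin-1-yl. Compound 4 moves the other way, to a ring of carbon only with no hydrogen-bond acceptors, so a large drop in this assay is expected, landing near the number of compound 1, 7000 nM.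

For compound 4 the expected value in this assay is 5000 nM, with a range from 1500 nM to 15000 nM, which is an expected step of a 17-fold lower number from compound 3 to compound 4 (1.22 log units; beyond the scatter).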

Compound 4, solubility: 39000 nM
Compound 4: the middle estimate sits 7.8-fold (0.89 log units) below what was measured; the measured number lies above the stated range.
By their numbers in this assay, from the lowest: compound 1; then compound 4; then compound 3; then compound 2.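

At this carbon, a ring of carbon only with no hydrogen-bond acceptors did not give the lowest number in this assay: 4-fluorophenyl in place of 5-fluoropyridin-2-yl gave (a 5.6-fold higher number from compound 1 to compound 4 (0.75 log units; beyond the scatter)), so the bottom of the series belongs to compound 1. For the compounds shown here, the same ring lost only a little against 1-methyl-1H-pyrazol-5-yl (a 2.1-fold lower number from compound 3 to compound 4 (0.33 log units; beyond the scatter)) and more against piperazin-1-yl (a 7.4-fold lower number from compound 2 to compound 4 (0.87 log units; beyond the scatter)), which places compound 4 within the range already spanned by the earlier compounds. The order at this position therefore does not simply follow the presence of hetero atoms in the entering ring, with compound 1 standing against such a pattern, and nothing available accounts for why the two fluorinated six-membered rings differ.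

The compounds shown leave open whether the fluorine matters, since an unsubstituted phenyl ring at this carbon would separate its contribution from that of the ring itself. They also leave open how a morpholine ring, an open-chain amine such as dimethylamino or a carboxylic acid would compare with piperazin-1-yl, which holds the highest number in this series.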